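The compounds below may be only part of what the source reports. "The series", "measured", "known", "first", "only" and "open" are said of these compounds alone.

Measured so far:
Compound 1 `CO[C@@H]1CC=C2NN(c3ccc(C)cc3)C(=O)C[C@]2(C)O1`: 28700 nM
Compound 2 `CO[C@@H]1CC=C2NN(c3cc4ccccc4[nH]3)C(=O)C[C@]2(C)O1`: 18300 nM

Both numbers come from a functional assay on HCT-116 cells (Homo sapiens) for inhibition, read by sulforhodamine B assay, with a stated time of 48 h; a higher number here means a weaker inhibitor, a lower number a stronger inhibitor. Compound 2 holds the lower of the two numbers, but the gap to compound 1 lies within the scatter, so no order between the two compounds can be stated; the two values are read as equivalent for present purposes.

Compound 3 `CO[C@@H]1CC=C2NN(c3cc4ccccc4[nH]3)C(=O)C[C@]2(c2ccncc2)O1` is the next entry and has not yet been measured. It differs from compound 2 in one place: pyridin-4-yl in place of methyl on a saturated ring carbon. Going by the values given here, no pair of measured compounds differs at this position, so there is no precedent for how this saturated ring carbon responds to a larger substituent, and the only anchor is the value of compound 2. On that basis the step of a 1.2-fold lower number from compound 2 to compound 3 (0.09 log units; within the scatter) is expected to be small, of no clear size beyond the scatter, with the direction left open. Compound 3 is expected to give about 15000 nM, with a plausible range from 4000 nM to 50000 nM, the width reflecting the absence of any comparable change among the measured compounds.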

Compound 3, half-maximal inhibitory concentration: 4350 nM
Beside the measured number, compound 3's estimate is 3.4-fold (0.54 log units) above it; the measured number falls inside the stated range.
By their numbers in this assay, from the lowest: compound 3; then compounds 2 and 1 (each within the scatter of the next).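

In this assay, going by these compounds alone, pyridin-4-yl in place of methyl on the saturated ring carbon next to the ring oxygen gives a 4.2-fold lower number from compound 2 to compound 3 (0.62 log units; beyond the scatter) and is the first step to lie beyond the scatter. Within the data shown here, this position therefore responds to substitution, a point the earlier compounds could not address, and the larger group, with its six-membered aromatic ring, comes with a lower number rather than a loss of inhibition at this carbon. Among these compounds, no measurement at hand accounts for the step, so the single pair records the size and direction of the change without giving a reason for it.

Going by these compounds, whether the gain depends on the ring nitrogen or on the ring alone remains open: phenyl at this carbon would separate the two, while pyridin-2-yl would test the place of the nitrogen, and piperidin-4-yl or a longer alkyl chain would test the need for an aromatic ring. Also open, on these data alone, is whether pyridin-4-yl gives a similar step on the core carrying the ring substituent of compound 1.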